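Swapping a chain with an ether ring at compound 4

The source may report more compounds than this note shows. Statements on the series, on what has been measured and on what is new or still open speak of the compounds shown alone.

Three measured compounds share one core and differ only in what hangs on the outer amine nitrogen. Compound 1 `c1ccc2c(c1)CN[C@@H](CN(CCCCNCc1ccncc1)[C@H]1CCCc3cccnc31)C2` carries a (pyridin-4-yl)methyl group there and in a functional assay on cells for antagonist activity at C-X-C chemokine receptor type 4 (Homo sapiens), read by fluorescence and calcium flux, with stated times of 25 min and 90 s (on this read-out higher numbers stand for weaker inhibition and lower numbers for stronger inhibition), compound 1 gives 22.7 nM. Compound 2 `c1ccc2c(c1)CN[C@@H](CN(CCCCNC1CCCCC1)[C@H]1CCCc3cccnc31)C2` carries cyclohexyl instead, and in this assay compound 2 gives 75.2 nM; that change is a 3.3-fold higher number from compound 1 to compound 2 (0.52 log units; beyond the scatter). Compound 3 `c1ccc2c(c1)CN[C@@H](CN(CCCCNC1CCOCC1)[C@H]1CCCc3cccnc31)C2` carries oxan-4-yl, and in this assay compound 3 gives 29.4 nM, which is a 1.3-fold higher number from compound 1 to compound 3 (0.11 log units; within the scatter) and a 2.6-fold lower number from compound 2 to compound 3 (0.41 log units; beyond the scatter). On these numbers compound 3 stands second highest of the three, close to compound 1 and clearly lower than compound 2.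

Compound 4 `C(=C/CN(C[C@H]1Cc2ccccc2CN1)[C@H]1CCCc2cccnc21)\CNCC1CCOCC1` is not yet measured. Its difference from compound 3 is a group of 11 heavy atoms (9 carbon, 1 nitrogen, 1 oxygen; one six-membered non-aromatic ring with 1 hetero atom) in place of a group of 10 heavy atoms (8 carbon, 1 nitrogen, 1 oxygen; one six-membered non-aromatic ring with 1 hetero atom), on a saturated chain carbon bound to an amine nitrogen. Going by the values given here, the change lies in the chain itself, not in the group on the outer nitrogen, so none of the measured steps bears directly on it; the three steps only show that the terminal ring and its replacements move the number by modest amounts at most. With no guide for a chain change, the expectation for compound 4 is a step close to none beyond the scatter, a 1.2-fold higher number from compound 3 to compound 4 (0.09 log units; within the scatter), giving an estimated value for compound 4 of 36 nM, with a range from 12 nM to 110 nM.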

Compound 4, half-maximal inhibitory concentration: 24.2 nM
Beside the measured number, compound 4's estimate is 1.5-fold (0.17 log units) above it; the measured number falls inside the stated range.
By their numbers in this assay, from the lowest: compounds 1, 4 and 3 (each within the scatter of the next); then compound 2.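

In this assay, going by these compounds alone, the group with one double bond outside aromatic rings, set on a saturated chain carbon bound to an amine nitrogen in place of 3-((oxan-4-yl)amino)propyl, gives a 1.2-fold lower number from compound 3 to compound 4 (0.08 log units; within the scatter), so the first change in the chain itself leaves the number within the scatter, where the earlier compounds varied only the group on the outer nitrogen. The new group also keeps compound 4 on the same side of the one clear gap in this small set as compound 3: the step from the cyclohexyl compound is a 3.1-fold lower number from compound 2 to compound 4 (0.49 log units; beyond the scatter), while the step from the compound with the aromatic ring is a 1.1-fold higher number from compound 1 to compound 4 (0.03 log units; within the scatter). No measurement is at hand that explains why the new group is tolerated here.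

The compounds shown leave open how much of this result belongs to the double bond and how much to the other differences between the two groups, as these arrive together in one swap. Also open, on these data alone, is how a longer chain, or a triple bond in place of the double bond, would read in this assay.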